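The source may report more compounds than this note shows. Statements on the series, on what has been measured and on what is new or still open speak of the compounds shown alone.

In a functional assay on J774 cells (Mus musculus) for cytotoxicity, read by resazurin assay (on this read-out lower numbers stand for stronger inhibition and higher numbers for weaker inhibition), compound 1 (`OCCCCCC(O)c1ccc(-c2ccccc2F)cc1`) gives 22000 nM, compound 2 (`OCCCCCC(O)c1ccc(-c2ccc(F)cc2)cc1`) gives 18000 nM and compound 3 (`Cc1ccc(-c2ccc(C(O)CCCCCO)cc2)cc1`) gives 22000 nM, so compound 2 cannot be separated from the other two. Compound 4 (`OCCCCCC(O)c1ccc(-c2ccc(F)cc2)cc1F`) differs from compound 2 by fluoro in place of hydrogen on an aromatic carbon. For the measured compounds named here, no measured step makes this change. The nearest evidence is indirect: swaps on the 4-fluorophenyl group gave a 1.2-fold lower number from compound 1 to compound 2 (0.09 log units; within the scatter), a 1.2-fold higher number from compound 2 to compound 3 (0.09 log units; within the scatter) and no change at the digits printed from compound 1 to compound 3 (within the scatter). On that evidence, no step beyond the scatter is expected in this assay. The expected step is a 1.1-fold lower number from compound 2 to compound 4 (0.02 log units; within the scatter). Compound 4 is estimated at 17000 nM, with an expected range of 9000 nM to 32000 nM.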

Compound 4, half-maximal inhibitory concentration: 14000 nM
Compound 4: the middle estimate sits 1.2-fold (0.08 log units) above what was measured, within the range that was stated.
By their numbers in this assay, from the lowest: compounds 4, 2, 1 and 3 (each within the scatter of the next).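

In this assay, fluoro in place of hydrogen on an aromatic carbon, ortho to a group of 8 heavy atoms and meta to a 4-fluorophenyl group, gives a 1.3-fold lower number from compound 2 to compound 4 (0.11 log units; within the scatter) and so no separable change. The earlier steps shown here were swaps on the 4-fluorophenyl group alone; this one shows that a single added fluoro at this other position also stays within the scatter. No measurement on hand offers any explanation of this result.

As far as these compounds go, whether an amine or a carboxylic acid at this position, or a longer chain on the shared core, would move the number beyond the scatter stays open.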